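Compound 4: ethynyl in place of phenyl

The source may hold more compounds than are shown below. What is called first, only, known or untested is meant among the compounds shown, and "the series" means these compounds.

In an ADME assay on BJ cells (Homo sapiens), read by MTT assay, with a stated time of 72 h (on this read-out lower numbers stand for stronger inhibition and higher numbers for weaker inhibition), compound 3 `CNc1ncnc2c1c(-c1ccccc1)cn2[C@@H]1O[C@H](CO)[C@@H](O)[C@H]1O` gives > 100000 nM, which is a limit of the assay and not a number. Compound 4 `C#Cc1cn([C@@H]2O[C@H](CO)[C@@H](O)[C@H]2O)c2ncnc(NC)c12` carries ethynyl in place of phenyl on an aromatic carbon. Compound 2 `CNc1ncnc2c1c(-c1ccco1)cn2[C@@H]1O[C@H](CO)[C@@H](O)[C@H]1O`, with furan-2-yl at that place, gives 5040 nM. Going by the values given here, the one measured step at that place, an at least 19-fold higher number from compound 2 to compound 3 (1.29 log units; beyond the scatter), is large, and it ends on phenyl with the higher number. Compound 1 `C#Cc1cn([C@@H]2O[C@H](CO)[C@@H](O)[C@H]2O)c2ncnc(OC)c12`, which also bears ethynyl, gives 98400 nM, so only a moderate gain is expected. In this assay, the expected change is a move to a lower number, estimated as an at least 5.0-fold lower number from compound 3 to compound 4 (0.69 log units; beyond the scatter). Compound 4 is estimated at 20000 nM, with an expected range of 3000 nM to 100000 nM.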

Compound 4, half-maximal inhibitory concentration: 86000 nM
Estimate against measurement, compound 4: 4.3-fold (0.63 log units) below; measured number inside the range.
By their numbers in this assay, from the lowest: compound 2; then compounds 4 and 1 (each within the scatter of the next). At a limit, above all of these: compound 3.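

In this assay, ethynyl on this aromatic carbon does not reach the furan-2-yl result, with a 17-fold higher number from compound 2 to compound 4 (1.23 log units; beyond the scatter), so with methylamino on the core, furan-2-yl alone stands apart among the three groups. Compound 3 sits at a limit of the assay and not at a number, so an at least 1.1-fold lower number from compound 3 to compound 4 (0.06 log units; that floor lies within the scatter) gives only a floor: the limit of > 100000 nM in this assay, at which 1 of the 4 values shown sits. With ethynyl in place, methylamino in place of methoxy separates nothing, at a 1.1-fold lower number from compound 1 to compound 4 (0.06 log units; within the scatter). Going by these compounds, whether thiophen-2-yl would keep the lower number of furan-2-yl remains open, as does the outcome for a small alkyl chain such as ethyl at this place.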